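A Chloro Group Moved Onto the Pyridine Ring

The source may hold more compounds than are shown below. What is called first, only, known or untested is meant among the compounds shown, and "the series" means these compounds.

Of the compounds shown here, three have been measured in a functional assay for inhibition of sodium/hydrogen exchanger (Oryctolagus cuniculus); a higher number here means a weaker inhibitor, a lower number a stronger inhibitor. Compound 2, `Cc1ccc(S(C)(=O)=O)cc1C(=O)N=C(N)N`, is the simplest of them and gives 150 nM. Compound 1, `Cc1cc(Cl)c(S(C)(=O)=O)cc1C(=O)N=C(N)N`, carries one extra atom; the difference is chloro in place of hydrogen on an aromatic carbon, and that step is a 6.0-fold lower number from compound 2 to compound 1 (0.78 log units; beyond the scatter), leaving compound 1 at 25 nM. Compound 3, `Cc1cc(Oc2cccnc2)c(S(C)(=O)=O)cc1C(=O)N=C(N)N`, carries a larger group at the same place; the difference from compound 2 is (pyridin-3-yl)oxy in place of hydrogen on an aromatic carbon, the step is a 17-fold lower number from compound 2 to compound 3 (1.23 log units; beyond the scatter), and the step from compound 1 is a 2.8-fold lower number from compound 1 to compound 3 (0.45 log units; beyond the scatter), so compound 3 gives 8.8 nM and has the lowest number of the three.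

Compound 4, `Cc1cc(Oc2cncc(Cl)c2)c(S(C)(=O)=O)cc1C(=O)N=C(N)N`, has not yet been measured. It is built on the core of compound 3, and the difference is chloro in place of hydrogen on an aromatic carbon. Going by the values given here, this is the same kind of change as the one from compound 2 to compound 1, but not the same change: in compound 1 the chloro sits on a six-membered aromatic ring of carbon only, ortho to a methylsulfonyl group, meta to a methyl group and para to a group of 6 heavy atoms, whereas in compound 4 it sits on a six-membered aromatic ring with 1 nitrogen, two atoms from the ring nitrogen and meta to a large group. Among the compounds with values here, only one earlier example of a chloro for hydrogen exists here, and it was made at a different place, so the earlier step is a weak guide. For compound 4 in this assay a smaller step is expected, a 1.5-fold lower number from compound 3 to compound 4 (0.17 log units; within the scatter), and the number is estimated at 6 nM, most likely between 2.5 nM and 15 nM.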

Compound 4, half-maximal inhibitory concentration: 14 nM
Compound 4: the middle estimate sits 2.3-fold (0.37 log units) below what was measured; low and high end bracket the measured number.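

The chloro for hydrogen change did not behave alike on the two cores in this assay: the same change on two cores in this assay, a 6.0-fold lower number (0.78 log units; beyond the scatter) from compound 2 to compound 1 and a 1.6-fold higher number (0.20 log units; within the scatter) from compound 3 to compound 4, 9.5-fold (0.98 log units) apart, beyond the scatter of two such steps. On the pyridine ring the step reads a 1.6-fold higher number from compound 3 to compound 4 (0.20 log units; within the scatter), so the chloro there makes no readable difference; the whole (5-chloropyridin-3-yl)oxy group still gives an 11-fold lower number from compound 2 to compound 4 (1.03 log units; beyond the scatter), and set against a lone chloro on the shared core it gives a 1.8-fold lower number from compound 1 to compound 4 (0.25 log units; within the scatter), again no readable difference. This shows that a chloro for hydrogen step seen at one place is a poor guide to the same change at another place in this series, but it rests on a single pair of steps, so it does not show whether the core or the place on it decides the outcome, and it gives no reason for the gap.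

The compounds shown leave open whether a different group on the pyridine ring, such as methyl, methoxy or an amine, would shift the number beyond the scatter. They also leave open whether chloro on another carbon of that ring would act as it does in compound 4.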